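From 3-methylthiophen-2-yl to 2-methoxyphenyl: working notes

The source may hold more compounds than are shown below. What is called first, only, known or untested is meant among the compounds shown, and "the series" means these compounds.

Among the measured compounds shown here, in a functional assay on DU-145 cells (Homo sapiens) for inhibition, read by trypan blue exclusion, with a stated time of 96 h (a lower number here means a stronger inhibitor of growth, a higher number a weaker inhibitor of growth), compound 1 (`Cc1ccc(S/C(=C/c2sccc2C)C(=O)c2ccc(Br)cc2)cc1`) gives 50000 nM and stands level with compound 2 (`O=C(O)c1ccc(C(=O)/C(=C\c2ccc(O)c([N+](=O)[O-])c2)SCc2ccc(Br)cc2)cc1`) at 50000 nM on the numbers so far. Compound 3 (`COc1cc(/C=C(\C(=O)c2ccc(Cl)cc2)S(=O)(=O)Cc2ccccc2Cl)cc(OC)c1`) reads > 100000 nM in this assay and this is a limit of the assay, not a number.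

Compound 4 (`COc1ccccc1/C=C(/Sc1ccc(C)cc1)C(=O)c1ccc(Br)cc1`) carries 2-methoxyphenyl in place of 3-methylthiophen-2-yl on a double-bonded chain carbon bound to a double-bonded chain carbon. For the measured compounds named here, no measured step covers this exchange, so in this assay no shift beyond the scatter is expected in either direction. The expected step (a 1.7-fold lower number from compound 1 to compound 4 (0.22 log units; within the scatter)) is therefore small. Compound 4 is estimated at 30000 nM with 6000 nM to 100000 nM as the expected range.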

Compound 4, concentration for 50% growth inhibition: 9000 nM
Compound 4: the middle estimate sits 3.3-fold (0.52 log units) above what was measured; low and high end bracket the measured number.
By their numbers in this assay, from the lowest: compound 4; then compounds 1 and 2 (each within the scatter of the next). At a limit, above all of these: compound 3.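

In this assay, among the compounds shown here, 2-methoxyphenyl in place of 3-methylthiophen-2-yl gives a 5.6-fold lower number from compound 1 to compound 4 (0.74 log units; beyond the scatter), the first single-place step. For the compounds shown here, the earlier compounds differ from one another in more than one place, so only this step shows that the group at this position can move the number. No measured property on hand bears on this step.

Whether the methoxy group or the six-membered aromatic ring carries the step stays open, with an unsubstituted phenyl not among the compounds shown. Going by these compounds, how an amine or a carboxylic acid on that ring would read also stays open.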